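Side-chain variation and tolerated concentration in this series

A few compounds are considered here, and "the series" means these few. Any claim that something is new, unique, unknown or untested is made for them only; others in the source may bear on it.

Within the data shown here, in an ADME assay on MT2 cells (Homo sapiens) for inhibition (a lower number here means that less compound is tolerated, a higher number that more compound is tolerated), compound 2 `N#Cc1ccc(Nc2ncc(Cc3c(F)cc(CC4CC4)cc3F)o2)cc1Cl` gives 29000 nM, the lowest of the two numbers measured so far. Among the measured compounds shown here, its only neighbour is compound 1 `N#Cc1ccc(Nc2ncc(Cc3c(F)cc(C4CC4)cc3F)o2)cc1Cl`, which in this assay gives 65000 nM; the single measured step is a 2.2-fold lower number from compound 1 to compound 2 (0.35 log units; beyond the scatter), a change of side chain on the shared core.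

Compound 3 `COCc1cc(F)c(Cc2cnc(Nc3ccc(C#N)c(Cl)c3)o2)c(F)c1` differs from compound 2 by methoxy in place of cyclopropyl on a saturated chain carbon bound to an aromatic carbon. For the measured compounds named here, the one measured step bears on it only loosely: it sits at the same part of the molecule and was modest in size, but it exchanged one carbon-only group for another, whereas here an oxygen-containing group enters and the three-membered ring leaves. Going by the values given here, no measured pair shows what that exchange does in this assay, so the direction rests on the small size of the known step rather than on a precedent. A step of similar magnitude, most likely back toward the number of compound 1 or none beyond the scatter, is expected, and the expected step is a 1.6-fold higher number from compound 2 to compound 3 (0.19 log units; within the scatter). Compound 3 is therefore estimated at 45000 nM, with a range from 15000 nM to 130000 nM.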

Compound 3, half-maximal cytotoxic concentration: 15000 nM
Beside the measured number, compound 3's estimate is 3.0-fold (0.48 log units) above it, within the range that was stated.
By their numbers in this assay, from the lowest: compounds 3 and 2 (each within the scatter of the next); then compound 1.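

In this assay, the exchange of cyclopropyl for methoxy on a saturated chain carbon bound to an aromatic carbon gives a 1.9-fold lower number from compound 2 to compound 3 (0.29 log units; within the scatter), so at this position an oxygen-containing chain end with one hydrogen-bond acceptor and no ring cannot be told apart from the cyclopropylmethyl side chain. Measured from the directly ring-bearing compound, methoxymethyl in place of cyclopropyl on an aromatic carbon gives a 4.3-fold lower number from compound 1 to compound 3 (0.64 log units; beyond the scatter), a larger step than a 2.2-fold lower number from compound 1 to compound 2 (0.35 log units; beyond the scatter), and both of these lie beyond the scatter, so among these three compounds the two with a side chain that starts with a saturated chain carbon sit apart from compound 1, with no compound here going against that. No measurement at hand accounts for these numbers.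

Still open, going by these compounds, is whether the chain carbon alone separates compound 2 and compound 3 from compound 1, or whether the group it carries also contributes, a question that a plain methyl or ethyl group at this position would bear on. Equally open, on these data alone, is how an amine, a carboxylic acid or a longer ether chain on the same saturated carbon would read in this assay.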